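This account rests on a few compounds, and the source may have more. Where it says the series, first, only, none or still open, it means among the compounds named here.

In an assay on isolated protein for displacement of a labelled ligand from metabotropic glutamate receptor 5 (Homo sapiens), with a stated time of 60 min, tested at 1 uM (on this read-out higher numbers stand for more inhibition at the one concentration tested (going by the name of the read-out) and lower numbers for less inhibition), compound 1 `Cc1ccc2ncc(S(=O)(=O)c3ccc(F)cc3)c(N3CCC(C)CC3)c2c1` gives 90%, compound 2 `Cc1ccc2ncc(S(=O)(=O)c3cc(F)cc(F)c3)c(N3CCC(C)CC3)c2c1` gives 72%, and compound 3 `COc1ccc2ncc(S(=O)(=O)c3cc(F)cc(F)c3)c(N3CCC(C)CC3)c2c1` gives 30%, the lowest of the three. The two cores differ by methoxy in place of methyl on an aromatic carbon, a change that moved the read-out a number 42 percentage points lower from compound 2 to compound 3 (beyond the scatter). Compound 4 `COc1ccc2ncc(S(=O)(=O)c3ccc(F)cc3)c(N3CCC(C)CC3)c2c1` is not yet measured in this assay. It differs from compound 3 by 4-fluorophenyl in place of 3,5-difluorophenyl on a sulfonyl sulfur, the same change as 4-fluorophenyl in place of 3,5-difluorophenyl on a sulfonyl sulfur, which gave a number 18 percentage points higher from compound 2 to compound 1 (beyond the scatter). Since the change from compound 2 to compound 1 raised the read-out by a number 18 percentage points higher from compound 2 to compound 1 (beyond the scatter), a step of similar size is expected here, a number 18 percentage points higher from compound 3 to compound 4 (beyond the scatter), though compound 2 and compound 3 start from different levels and the two examples are too few to fix the size firmly. On that basis compound 4 is expected to reach about 48% in this assay.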

Compound 4, a percentage reported as inhibition, at one concentration (the size of the read-out at that concentration, not a potency): 27%
Compound 4: the middle estimate sits 21 percentage points above what was measured; the whole stated range lies above it.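

In this assay, 4-fluorophenyl in place of 3,5-difluorophenyl on a sulfonyl sulfur gave a number 3 percentage points lower from compound 3 to compound 4 (within the scatter), so the rise seen on the methyl core did not carry over to the methoxy core: the same change on two cores in this assay, a number 18 percentage points higher (beyond the scatter) from compound 2 to compound 1 and a number 3 percentage points lower (within the scatter) from compound 3 to compound 4, 21 percentage points apart, beyond the scatter of two such steps. Methoxy in place of methyl on an aromatic carbon again gave a lower number, a number 63 percentage points lower from compound 1 to compound 4 (beyond the scatter), but the size of the step depended on the sulfonyl group: the same change on two cores in this assay, a number 42 percentage points lower (beyond the scatter) from compound 2 to compound 3 and a number 63 percentage points lower (beyond the scatter) from compound 1 to compound 4, 21 percentage points apart, beyond the scatter of two such steps. The two changes therefore do not add up across these four compounds, though the data do not show why, nor whether this holds beyond them.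

On these data alone, it remains open how a nitrile in place of the methyl or methoxy would behave. Also open, as far as these compounds go, is whether a 4-chlorophenyl on the sulfonyl sulfur would follow either core's pattern.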